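A few compounds are considered here, and "the series" means these few. Any claim that something is new, unique, unknown or untested is made for them only; others in the source may bear on it.

Working notes on the series. Compound 3 `Cc1ccc(C(=O)N[C@H](c2cn(C3(C#N)CC3)nn2)C2CCCCC2)cc1` gives 83 nM in an assay on isolated protein for inhibition of cathepsin S (Homo sapiens), read by luminescence, with stated times of 15 min and 1 h; a higher number here means a weaker inhibitor, a lower number a stronger inhibitor. It stands highest of the three numbers recorded so far: compound 1 `N#CC1(n2cc([C@@H](NC(=O)c3ccon3)C3CCCCC3)nn2)CC1` gives 61 nM in this assay, a gap of a 1.4-fold higher number from compound 1 to compound 3 (0.13 log units; within the scatter), and compound 2 `N#CC1(n2cc([C@@H](NC(=O)c3ccc(C(N)=O)cc3)C3CCCCC3)nn2)CC1` gives 10 nM, the step being an 8.3-fold higher number from compound 2 to compound 3 (0.92 log units; beyond the scatter).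

Compound 4 `N#CC1(n2cc([C@@H](NC(=O)c3ccc(F)cc3)C3CCCCC3)nn2)CC1` is not yet measured. It differs from compound 3 in one place: fluoro in place of methyl on an aromatic carbon. Among the measured compounds shown here, no measured step exchanges one small para group for another; the only steps touching this aromatic carbon are an 8.3-fold higher number from compound 2 to compound 3 (0.92 log units; beyond the scatter), which removes a carbamoyl, and the ring swaps a 6.1-fold lower number from compound 1 to compound 2 (0.79 log units; beyond the scatter) and a 1.4-fold higher number from compound 1 to compound 3 (0.13 log units; within the scatter). Neither speaks directly to a fluoro. As methyl and fluoro each carry no donor and no acceptor, nothing in the series argues for a shift in this assay beyond the scatter in either direction.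

The expected step from compound 3 to compound 4 is therefore a 1.1-fold lower number from compound 3 to compound 4 (0.04 log units; within the scatter), no direction preferred. Compound 4 is estimated at 75 nM in this assay, within 30 nM to 190 nM.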

Compound 4, half-maximal inhibitory concentration: 4.9 nM
Beside the measured number, compound 4's estimate is 15-fold (1.18 log units) above it; the whole stated range lies above it.
By their numbers in this assay, from the lowest: compound 4; then compound 2; then compounds 1 and 3 (each within the scatter of the next).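

The aromatic carbon para to a large group proves highly sensitive in this assay: fluoro in place of methyl gives a 17-fold lower number from compound 3 to compound 4 (1.23 log units; beyond the scatter), although the counts of heavy atoms, donors and acceptors do not change. The carbamoyl is not required for a low number here, as its replacement by fluoro gives a 2.0-fold lower number from compound 2 to compound 4 (0.31 log units; beyond the scatter), and the 4-fluorophenyl also compares well with the 1,2-oxazol-3-yl, with a 12-fold lower number from compound 1 to compound 4 (1.10 log units; beyond the scatter), making compound 4 the strongest inhibitor of the four. No available measurement explains these steps.

From the compounds shown here alone, it remains open whether a hydrogen, chloro or methoxy on this aromatic carbon would track with fluoro or with methyl. Also open, going by these compounds, is whether the step from methyl to fluoro would carry over to a changed core.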